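The source may hold more compounds than are shown below. What is called first, only, known or untested is meant among the compounds shown, and "the series" means these compounds.

Compound 3 `CCOC(=O)c1cnc(N2CCN(Cc3ccc(F)cc3)CC2)nc1Oc1c(C)cc(-c2ccc(C#N)cc2)cc1C` has been tested in an ADME assay on MT4 cells (Homo sapiens) for cytotoxicity, read by MTT assay, with a stated time of 4 days; a higher number here means that more compound is tolerated, a lower number that less compound is tolerated. In this assay compound 3 gives > 117000 nM, which is a limit of the assay and not a number. The related compound 1 `CCOC(=O)c1cnc(N2CCN(Cc3ccccc3C#N)CC2)nc1Oc1c(C)cc(-c2ccc(C#N)cc2)cc1C` also gives only a limit, > 125000 nM. Compound 2 `CCOC(=O)c1cnc(N2CCN(Cc3ccccc3C(F)(F)F)CC2)nc1Oc1c(C)cc(-c2ccc(C#N)cc2)cc1C` likewise gives a limit, > 125000 nM. All three values shown are thus limits: the limit of > 125000 nM in this assay, at which 2 of the 3 values shown sit, and (the limit of > 117000 nM in this assay, at which 1 of the 3 values shown sits). The measured steps among them carry no readable size: a step that the two limits leave unreadable from compound 1 to compound 2, a step that the two limits leave unreadable from compound 1 to compound 3 and a step that the two limits leave unreadable from compound 2 to compound 3.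

The next step goes from compound 3 to compound 4 `CCOC(=O)c1cnc(N2CCN(Cc3ccc(C(=O)OC)cc3)CC2)nc1Oc1c(C)cc(-c2ccc(C#N)cc2)cc1C`. The change is methoxycarbonyl in place of fluoro on an aromatic carbon. Seen one bond further out it reads 4-fluorobenzyl to 4-(methoxycarbonyl)benzyl. The measured changes also sit on this benzyl group, but none of them carried a readable size, so they give no direction for this assay, neither upward nor downward; they only show that every variant so far was tolerated up to the limit. Compound 4 is expected to show no step beyond the scatter: a step that the limit leaves unreadable from compound 3 to compound 4. Compound 4 is estimated at 125000 nM, with a range from 60000 nM to 250000 nM, and will most likely be reported once more only as a limit.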

Compound 4, half-maximal cytotoxic concentration: > 125000 nM
Compound 4: a limit, no number (the forecaster's own chance of this, stated with the estimate: 80%); the middle value sits exactly at the limit.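

In this assay compound 4 gives > 125000 nM, which is a limit of the assay and not a number. The steps linking compound 4 to compound 1, compound 2 and compound 3 cannot be read, since all four values are limits. The compounds shown leave open at what concentration any of them becomes cytotoxic, and whether the benzyl changes shift that concentration at all.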